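The source may report more compounds than this note shows. Statements on the series, on what has been measured and on what is new or still open speak of the compounds shown alone.

Compound 1 `CCCOc1c(-c2cc(OC)c(OC)c(OC)c2)oc2ccccc2c1=O` carries a propyl group on an oxygen of the shared core. Within the data shown here, in a functional assay on DU-145 cells (Homo sapiens) for antiproliferative activity, read by WST assay, with a stated time of 3 days (a higher number here means a weaker inhibitor, a lower number a stronger inhibitor), compound 1 gives 2800 nM, the only actual number among the three measured compounds. Compound 2 `CCCCCCOc1c(-c2cc(OC)c(OC)c(OC)c2)oc2ccccc2c1=O` carries a hexyl chain at the same oxygen. In this assay compound 2 gives only a limit, > 50000 nM. Compound 3 `CCCC(C)Oc1c(-c2cc(OC)c(OC)c(OC)c2)oc2ccccc2c1=O` carries a 1-methylbutyl group there. In this assay compound 3 likewise gives only a limit, > 50000 nM. The step of an at least 17-fold higher number from compound 1 to compound 2 (1.25 log units; beyond the scatter) shows that lengthening the chain by propyl in place of hydrogen on a saturated chain carbon, three bonds along the chain from an oxygen on an aromatic ring, costs a lot; the step of an at least 17-fold higher number from compound 1 to compound 3 (1.25 log units; beyond the scatter) points the same way. Between the two limits, a step that the two limits leave unreadable from compound 2 to compound 3.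

Compound 4 `CCCN(CCC)CCCCOc1c(-c2cc(OC)c(OC)c(OC)c2)oc2ccccc2c1=O` differs from compound 1 by (dipropylamino)methyl in place of hydrogen on a saturated chain carbon, three bonds along the chain from an oxygen on an aromatic ring. The change sits at exactly the place where the step from compound 1 to compound 2 was measured, and it adds a still larger group there. Compound 4 is therefore expected to be a weaker inhibitor, with a step of an 11-fold higher number from compound 1 to compound 4 (1.03 log units; beyond the scatter), quite possibly only a limit at the limit of > 50000 nM in this assay, at which 2 of the 3 values shown sit. The estimate for compound 4 is 30000 nM, within 6000 nM to 50000 nM.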

Compound 4, half-maximal inhibitory concentration: 35800 nM
The estimate for compound 4 lay 1.2-fold (0.08 log units) below the measured number; low and high end bracket the measured number.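

Compound 4 carries a long chain at this oxygen and still gives a real number, so in this assay the 4-(dipropylamino)butyl group stays within the measurable range, whereas the hexyl and 1-methylbutyl groups reach only a limit. The step of a 13-fold higher number from compound 1 to compound 4 (1.11 log units; beyond the scatter) is large, which shows that this longer, nitrogen-bearing chain is still far worse than the propyl group of compound 1, so adding the amine does not restore the activity of the short chain. The steps of an at least 1.3-fold lower number from compound 2 to compound 4 (0.14 log units; that floor lies within the scatter) and an at least 1.3-fold lower number from compound 3 to compound 4 (0.14 log units; that floor lies within the scatter) give only floors that lie within the scatter, so the 4-(dipropylamino)butyl group cannot yet be ranked against the hexyl or 1-methylbutyl groups: the limit of > 50000 nM in this assay, at which 2 of the 4 values shown sit.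

From the compounds shown here alone, it remains open whether a shorter group on this oxygen, such as ethyl or methyl, would give a lower number than propyl does, and at what chain length between propyl and hexyl the loss sets in. Going by these compounds, the part played by the dipropylamino end also remains open, since that would take a plain butyl chain, or a smaller dimethylamino group or a carboxylic acid at the same chain end, for comparison.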